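A Third Methoxy Group on the Carbonyl-Side Ring

The source may hold more compounds than are shown below. What is called first, only, known or untested is meant among the compounds shown, and "the series" means these compounds.

Of the compounds shown here, three sharing one core have been tested in a functional assay on T47D cells (Homo sapiens) for cytotoxicity, read by sulforhodamine B assay, with a stated time of 48 h, tested at 1 uM; a higher number here means a weaker effect of the compound at the concentration tested, a lower number a stronger effect. Compound 1 `COc1cc(-c2cc(/C=C/C(=O)c3ccc(N)cc3)[nH]n2)cc(OC)c1OC` gives 66%, compound 2 `COc1cc(-c2cc(/C=C/C(=O)c3ccc(Cl)c(Cl)c3)[nH]n2)cc(OC)c1OC` gives 62%, and compound 3 `COc1ccc(C(=O)/C=C/c2cc(-c3cc(OC)c(OC)c(OC)c3)n[nH]2)cc1OC` gives 75%. Compound 3 therefore carries the highest of the three numbers, meaning the weakest effect at the tested concentration; its nearest neighbour is compound 1, with the step of a number 9 percentage points higher from compound 1 to compound 3 (within the scatter), while the step of a number 13 percentage points higher from compound 2 to compound 3 (beyond the scatter) is a modest one beyond the scatter.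

Compound 4 `COc1cc(C(=O)/C=C/c2cc(-c3cc(OC)c(OC)c(OC)c3)n[nH]2)cc(OC)c1OC` differs from compound 3 in one place: methoxy in place of hydrogen on an aromatic carbon.

Within the data shown here, no measured step adds a methoxy group in this way; the steps that come closest swap the whole ring on the carbonyl carbon, as in a number 4 percentage points lower from compound 1 to compound 2 (within the scatter) and a number 13 percentage points higher from compound 2 to compound 3 (beyond the scatter), and all of them stayed small. A similar small shift, or none beyond the scatter, is expected here, with the estimated step of a number 3 percentage points higher from compound 3 to compound 4 (within the scatter). Compound 4 is thus estimated at 78%, within a range from 65% to 90%.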

Compound 4, a percentage reported as activity, at one concentration (the size of the read-out at that concentration, not a potency): 57%
The estimate for compound 4 lay 21 percentage points above the measured number; the measured number lies below the stated range.
By their numbers in this assay, from the lowest: compounds 4, 2, 1 and 3 (each within the scatter of the next, the first and the last beyond it).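

In this assay the added methoxy group gives a number 18 percentage points lower from compound 3 to compound 4 (beyond the scatter) and so a stronger effect at the tested concentration. Among these compounds, this is the first step here that changes a single substituent rather than swapping the whole ring on the carbonyl carbon, and it shows that one methoxy group, placed ortho to a methoxy group on that ring, can shift the read-out beyond the scatter. No measurement shown here explains the drop.

As far as these compounds go, whether this shift is specific to methoxy stays open, and a hydroxy or ethoxy group at the same place would test that. Also open, from the compounds shown here alone, is whether the shift would hold at other concentrations, since a single concentration gives the size of the read-out and not a potency.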